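The compounds below may be only part of what the source reports. "The series", "measured", "known", "first", "only" and "open" are said of these compounds alone.

Measured compounds in a functional assay on HepG2 cells (Homo sapiens) for inhibition, read by MTT assay, with a stated time of 72 h; on this read-out lower numbers stand for stronger inhibition and higher numbers for weaker inhibition:
compound 1 `CN(C(=O)NC(=O)c1c(F)cccc1F)c1nc(C(F)(F)F)c(C(=O)N/N=C/c2cccc(C(F)(F)F)c2)s1` gives 27.9 ug/mL
compound 2 `Cc1nc(N(C)C(=O)NC(=O)c2c(F)cccc2F)sc1C(=O)N/N=C/c1cccc(C(F)(F)F)c1` gives 31.6 ug/mL
compound 3 `Cc1nc(N(C)C(=O)NC(=O)c2c(F)cccc2F)sc1C(=O)N/N=C/c1cc(C(F)(F)F)cc(C(F)(F)F)c1` gives 11.4 ug/mL

Compound 2 has the highest of the three numbers in this assay. Its gap to compound 1 is within the scatter, as the step of a 1.1-fold higher number from compound 1 to compound 2 (0.05 log units; within the scatter) shows, so the two cannot be told apart. Compound 3 sits clearly lower, by the step of a 2.8-fold lower number from compound 2 to compound 3 (0.44 log units; beyond the scatter), a modest gain that comes with an added trifluoromethyl.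

Compound 4 `Cc1nc(N(C)C(=O)NC(=O)c2c(F)cccc2F)sc1C(=O)N/N=C/c1ccccc1C(F)(F)F` is the unmeasured compound. It differs from compound 2 only in this way: 2-(trifluoromethyl)phenyl in place of 3-(trifluoromethyl)phenyl on a carbon with a double bond to nitrogen. Among the measured compounds shown here, no measured step moves a trifluoromethyl from one place on that ring to another; the step from compound 2 to compound 3 adds a second such group, and the step from compound 1 to compound 2 changes a group on the shared core. Neither tells how rearranging one group will play out, so no step beyond the scatter is expected, a 1.1-fold lower number from compound 2 to compound 4 (0.02 log units; within the scatter). The number for compound 4 in this assay is therefore estimated at 30 ug/mL, likely between 12 ug/mL and 75 ug/mL.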

Compound 4, half-maximal inhibitory concentration: 1.11 ug/mL
For compound 4 the middle estimate is 27-fold (1.43 log units) above the measured one; the measured number lies below the stated range.
By their numbers in this assay, from the lowest: compound 4; then compound 3; then compounds 1 and 2 (each within the scatter of the next).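

In this assay, the place of a single trifluoromethyl on this ring proves to matter a great deal: with the same atoms joined differently, 2-(trifluoromethyl)phenyl in place of 3-(trifluoromethyl)phenyl gives a 28-fold lower number from compound 2 to compound 4 (1.45 log units; beyond the scatter). This is a much larger step than the earlier gain from adding a second trifluoromethyl, which gave a 2.8-fold lower number from compound 2 to compound 3 (0.44 log units; beyond the scatter), so on this ring the position of the group can count for more than the number of such groups. The data at hand offer no explanation for this difference.

Going by these compounds, it remains open whether the gain belongs to trifluoromethyl itself or would also appear with 2-chlorophenyl or 2-methoxyphenyl in the same place. It is also unknown whether 2-(trifluoromethyl)phenyl would bring a similar gain on the core of compound 1.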